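The source may hold more compounds than are shown below. What is called first, only, known or untested is meant among the compounds shown, and "the series" means these compounds.

Compound 1 `Cn1ccc2c(Oc3ccc(NC(=O)c4cc5cccnc5n(-c5ccc(Br)cc5)c4=O)cc3)ccnc21`: 690 nM
Compound 2 `Cn1ccc2c(Oc3ccc(NC(=O)c4cc5cccnc5n(-c5ccc(F)c(Cl)c5)c4=O)cc3)ccnc21`: 1210 nM

Of the compounds shown here, two have been measured in a functional assay on HT-29 cells (Homo sapiens) for antiproliferative activity, read by MTT assay, with a stated time of 72 h; a lower number here means a stronger inhibitor, a higher number a weaker inhibitor. Compound 1 `Cn1ccc2c(Oc3ccc(NC(=O)c4cc5cccnc5n(-c5ccc(Br)cc5)c4=O)cc3)ccnc21` gives 690 nM and compound 2 `Cn1ccc2c(Oc3ccc(NC(=O)c4cc5cccnc5n(-c5ccc(F)c(Cl)c5)c4=O)cc3)ccnc21` gives 1210 nM. The single step between them, a 1.8-fold higher number from compound 1 to compound 2 (0.24 log units; within the scatter), leaves the two numbers within the scatter of each other, so on the numbers shown compound 2 stands level with compound 1 rather than apart from it. Compound 3 `Cn1ccc2c(Oc3ccc(NC(=O)c4cc5cccnc5n(-c5ccc(C(F)(F)F)cc5Cl)c4=O)cc3)ccnc21` has not yet been measured. It differs from compound 2 in one place: 2-chloro-4-(trifluoromethyl)phenyl in place of 3-chloro-4-fluorophenyl on an aromatic nitrogen. Going by the values given here, the one measured step that bears on this change is likewise an exchange of the substituted phenyl on the aromatic nitrogen, a 1.8-fold higher number from compound 1 to compound 2 (0.24 log units; within the scatter), and it brought no shift beyond the scatter. On that basis no step beyond the scatter is expected in this assay from compound 2 to compound 3, a 1.0-fold lower number from compound 2 to compound 3 (0.00 log units; within the scatter). Compound 3 is therefore estimated at 1200 nM, with a range of 450 nM to 3200 nM.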

Compound 3, half-maximal inhibitory concentration: 6050 nM
Compound 3: the middle estimate sits 5.0-fold (0.70 log units) below what was measured, outside the stated range (above it).
By their numbers in this assay, from the lowest: compounds 1 and 2 (each within the scatter of the next); then compound 3.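

In this assay, the substituted phenyl on the aromatic nitrogen can move the number beyond the scatter: 2-chloro-4-(trifluoromethyl)phenyl raises it whether it replaces 3-chloro-4-fluorophenyl (a 5.0-fold higher number from compound 2 to compound 3 (0.70 log units; beyond the scatter)) or 4-bromophenyl (an 8.8-fold higher number from compound 1 to compound 3 (0.94 log units; beyond the scatter)). The earlier step between compound 1 and compound 2 stayed within the scatter, so only now does this position prove sensitive to the group it carries, and compound 3 stands as the weakest of the three. Nothing available accounts for this loss of activity.

From the compounds shown here alone, what stays open is which part of the exchange carries the step, the place of the chlorine or the trifluoromethyl. Also open, going by these compounds, is how an amine, a carboxylic acid or a longer alkyl chain on this phenyl would read in this assay.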